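Swapping chloro for hydroxy on the nitro-free phenyl ring

This account rests on a few compounds, and the source may have more. Where it says the series, first, only, none or still open, it means among the compounds named here.

Measured so far in a functional assay on HPLF cells (Homo sapiens) for cytotoxicity; on this read-out lower numbers stand for higher toxicity in this test and higher numbers for lower toxicity in this test:
compound 1, `COc1cc(/C=C2\Cc3ccccc3/C(=C\c3ccc([N+](=O)[O-])cc3)C2=O)ccc1O`, gives 21000 nM;
compound 2, `COc1cc(/C=C2\CCC/C(=C\c3ccc([N+](=O)[O-])cc3)C2=O)ccc1O`, gives 171000 nM;
compound 3, `O=C1/C(=C/c2ccc(Cl)cc2)CCC/C1=C\c1ccc([N+](=O)[O-])cc1`, gives 332000 nM.

Compound 3 holds the highest of the three numbers in this assay, though its gap to compound 2 is within the scatter; only compound 1 stands clearly apart. Compound 4, `O=C1/C(=C/c2ccc(O)cc2)CCC/C1=C\c1ccc([N+](=O)[O-])cc1`, differs from compound 3 by hydroxy in place of chloro on an aromatic carbon. Within the data shown here, the only measured step that touches this kind of exchange is a 1.9-fold higher number from compound 2 to compound 3 (0.29 log units; within the scatter), where a 4-chlorophenyl replaced a ring that also carried a hydroxy group. Undoing that exchange is therefore expected to move the number little, if at all, perhaps slightly downward. The step of a 1.5-fold lower number from compound 3 to compound 4 (0.18 log units; within the scatter) is the expectation, so compound 4 is estimated at 220000 nM, between 90000 nM and 550000 nM.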

Compound 4, half-maximal cytotoxic concentration: > 400000 nM
Compound 4 was reported as a limit; the forecaster's own chance of this, stated with the estimate: 25%; at least 1.8-fold (0.25 log units) between middle value and limit.
By their numbers in this assay, from the lowest: compound 1; then compounds 2 and 3 (each within the scatter of the next). At a limit, above all of these: compound 4.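

Compound 4 gives > 400000 nM in this assay, which is a limit and not a number. Hydroxy in place of chloro gives an at least 1.2-fold higher number from compound 3 to compound 4 (0.08 log units; that floor lies within the scatter), so this exchange on the aromatic carbon does not bring the number down. Hydrogen in place of methoxy gives an at least 2.3-fold higher number from compound 2 to compound 4 (0.36 log units; beyond the scatter), the first step on this ring that clears the scatter.

Going by these compounds, the real number for compound 4 stays unknown because the reading stops at a limit: the limit of > 400000 nM in this assay, at which 1 of the 4 values shown sits. On these data alone, whether an amine or a carboxylic acid on the same aromatic carbon would keep the number this high remains open.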